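Moving the amino group on the phenyl ring of a urea

This account rests on a few compounds, and the source may have more. Where it says the series, first, only, none or still open, it means among the compounds named here.

Measured compounds:
compound 1 `CC(C)c1cccc(C(C)C)c1NC(=O)NCC1(c2ccccc2C(F)(F)F)CCCC1` gives 18 nM
compound 2 `CC(C)c1cccc(C(C)C)c1NC(=O)NCC1(c2cccc(N)c2)CCCC1` gives 21 nM

In an assay on microsomes for inhibition of acyl-CoA:cholesterol acyltransferase (Oryctolagus cuniculus) (on this read-out lower numbers stand for stronger inhibition and higher numbers for weaker inhibition), compound 2 gives 21 nM and holds the highest of the two numbers, with compound 1 nearest at 18 nM. Going by the values given here, the one measured step is a 1.2-fold higher number from compound 1 to compound 2 (0.07 log units; within the scatter), which is within the scatter. Compound 3 `CC(C)c1cccc(C(C)C)c1NC(=O)NCC1(c2ccc(N)cc2)CCCC1` differs from compound 2 by 4-aminophenyl in place of 3-aminophenyl on a saturated ring carbon. Among the compounds with values here, no measured step moves the amino group from one place on the phenyl ring to another, so the single measured step, which swaps a different group, bears only loosely on this change; it shows that the shared core has tolerated an exchange on this phenyl ring without a change beyond the scatter. Compound 3 is therefore expected to fall near compound 2, with a 1.2-fold higher number from compound 2 to compound 3 (0.08 log units; within the scatter) as the estimated step. The estimate for compound 3 is 25 nM, with a range from 9 nM to 70 nM.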

Compound 3, half-maximal inhibitory concentration: 29 nM
For compound 3 the middle estimate is 1.2-fold (0.06 log units) below the measured one; the measured number falls inside the stated range.
By their numbers in this assay, from the lowest: compounds 1, 2 and 3 (each within the scatter of the next).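

Going by these compounds alone, compound 3 gives the first direct reading of where the amino group sits on the phenyl ring: in this assay, 4-aminophenyl in place of 3-aminophenyl gives a 1.4-fold higher number from compound 2 to compound 3 (0.14 log units; within the scatter), so the two placements cannot be told apart on this read-out. The exchange of 2-(trifluoromethyl)phenyl for 4-aminophenyl gives a 1.6-fold higher number from compound 1 to compound 3 (0.21 log units; within the scatter), so the three groups on the saturated ring carbon all lie within the scatter of one another. Nothing in the data available here accounts for these numbers.

Still open, going by these compounds, is how this assay responds to a hydroxyl group or a carboxylic acid in place of the amine on this phenyl ring, or to a longer chain such as aminomethyl. The compounds shown also leave open whether this tolerance would hold on a core other than the shared one.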